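The compounds below may be only part of what the source reports. "The series", "measured", "known", "first", "only" and "open" are said of these compounds alone.

In a physicochemical assay for lipophilicity (on this read-out higher numbers stand for higher lipophilicity and lower numbers for lower lipophilicity), compound 1 `CNC(=O)c1cc(C(=O)N[C@H]2CC[C@H](O)CC2)c([C@@H](C)c2cccc(OC)c2)o1` gives 2.9 and compound 2 `CNC(=O)c1cc(C(=O)N[C@H]2CC[C@H](O)CC2)c([C@@H](C)c2ccccc2Cl)o1` gives 3.1, so the two stand within the scatter of each other. Within the data shown here, the only measured step is a number 0.20 log units higher from compound 1 to compound 2 (within the scatter), with 2-chlorophenyl in place of 3-methoxyphenyl. Compound 3 `CNC(=O)c1cc(C(=O)N[C@H]2CC[C@H](O)CC2)c([C@@H](C)c2ccccc2)o1` differs from compound 2 by hydrogen in place of chloro on an aromatic carbon, ortho to a large group. The measured step exchanges different groups and bears only loosely on this change, yet a modest downward step is expected in this assay. The step is estimated as a number 0.40 log units lower from compound 2 to compound 3 (beyond the scatter). For compound 3 the expected value is 2.7, with an estimated range of 2.4 to 3.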

Compound 3, distribution coefficient: 2.8
Compound 3: middle estimate off by 0.10 log units, on the low side, within the range that was stated.
By their numbers in this assay, from the lowest: compounds 3, 1 and 2 (each within the scatter of the next).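

With compound 3, the aromatic ring carries neither chloro nor methoxy, so each group can be compared with hydrogen in this assay. Hydrogen in place of chloro gives a small step (a number 0.30 log units lower from compound 2 to compound 3 (within the scatter)), and hydrogen in place of methoxy gives another (a number 0.10 log units lower from compound 1 to compound 3 (within the scatter)); both lie within the scatter, so neither group separates its compound from compound 3 on this read-out. Nothing measured here offers an explanation for these small steps.

The compounds shown leave open whether an amine or a carboxylic acid on this aromatic ring would give a step beyond the scatter. They also leave open whether chloro would read the same elsewhere on the ring.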